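Replacing the hydroxy group of compound 2 with hydrogen

The source may report more compounds than this note shows. Statements on the series, on what has been measured and on what is new or still open speak of the compounds shown alone.

- compound 1 `COc1ccc2c(c1)/C(=C\c1c(OC)nc3sc(C)cn13)C(=O)N2` gives 42600 nM as its value
- compound 2 `COc1nc2sc(C)cn2c1/C=C1/C(=O)Nc2ccc(O)cc21` gives 63500 nM as its value

In a functional assay on cells (Ovarian carcinoma cell, Homo sapiens) for cytotoxicity, read by sulforhodamine B assay, with a stated time of 48 h (a higher number here means a weaker inhibitor of growth, a lower number a stronger inhibitor of growth), compound 2 stands at 63500 nM and lies within the scatter of compound 1 as a 1.5-fold higher number from compound 1 to compound 2 (0.17 log units; within the scatter) shows. Compound 3 `COc1nc2sc(C)cn2c1/C=C1/C(=O)Nc2ccccc21` carries hydrogen in place of hydroxy on an aromatic carbon. Among the compounds with values here, the only measured change at this hydroxy group is a 1.5-fold higher number from compound 1 to compound 2 (0.17 log units; within the scatter) and it is small, so no step beyond the scatter is expected in this assay and no direction can be favoured. An estimated 1.3-fold lower number from compound 2 to compound 3 (0.10 log units; within the scatter) is expected. Compound 3 is estimated at 50000 nM with a range from 22000 nM to 100000 nM expected.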

Compound 3, concentration for total growth inhibition: 55700 nM
Estimate against measurement, compound 3: 1.1-fold (0.05 log units) below; the measured number falls inside the stated range.
By their numbers in this assay, from the lowest: compounds 1, 3 and 2 (each within the scatter of the next).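

Hydrogen in place of hydroxy on an aromatic carbon gives a 1.1-fold lower number from compound 2 to compound 3 (0.06 log units; within the scatter) in this assay and so leaves the reading within the scatter. Hydrogen in place of methoxy at the same carbon gives a 1.3-fold higher number from compound 1 to compound 3 (0.12 log units; within the scatter) and is also within the scatter. With hydrogen now measured alongside hydroxy and methoxy, this position has three groups that this assay cannot tell apart, so the ring carbon appears to tolerate a bare hydrogen as well as an oxygen substituent.

Going by these compounds, whether an amine or a carboxylic acid on this carbon would read differently stays open. Nothing at hand explains why these three compounds read alike.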